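The source may report more compounds than this note shows. Statements on the series, on what has been measured and on what is new or still open speak of the compounds shown alone.

Measured in an ADME assay on the whole organism (Mus musculus, strain C57BL/6J) for pharmacokinetics, with a stated time of 24 h, at a dose of 2 mg/kg by the intravenous route; on this read-out higher numbers stand for fast clearance and lower numbers for slow clearance:
- compound 1 `CCc1cnc(OCC(C)(C)O)c(-c2ccc(S(C)(=O)=O)cc2)c1`: 65.6 mL/min/kg
- compound 2 `CCCCOc1nc(OCC(C)(C)O)c(-c2ccc(S(C)(=O)=O)cc2)cc1C(C)(C)O`: 58.8 mL/min/kg
- compound 3 `CCCCOc1nc(-c2ccc(F)cc2)c(-c2ccc(S(C)(=O)=O)cc2)cc1CO`: 32.2 mL/min/kg

Compound 3, at 32.2 mL/min/kg, lies within the scatter of compound 2 and beyond the scatter of compound 1, whose number is higher. Compound 4 `CCCCOc1nc(OCC2(O)CCC2)c(-c2ccc(S(C)(=O)=O)cc2)cc1CO` carries (1-hydroxycyclobutyl)methoxy in place of 4-fluorophenyl on an aromatic carbon, next to the ring nitrogen ((1-hydroxycyclobutyl)methoxy in place of 4-fluorophenyl on an aromatic carbon). Within the data shown here, no measured pair isolates this change. Compound 1 at 65.6 mL/min/kg and compound 2 at 58.8 mL/min/kg both carry a hydroxylated ether chain at that place, so a modest rise in this assay is expected, close to the scatter. The expected move is a 1.5-fold higher number from compound 3 to compound 4 (0.17 log units; within the scatter). Compound 4 is estimated at 48 mL/min/kg, with an expected range of 27 mL/min/kg to 80 mL/min/kg.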

Compound 4, clearance: 100 mL/min/kg
The estimate for compound 4 lay 2.1-fold (0.32 log units) below the measured number; the whole stated range lies below it.
By their numbers in this assay, from the lowest: compounds 3, 2, 1 and 4 (each within the scatter of the next, the first and the last beyond it).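

In this assay, among these compounds, (1-hydroxycyclobutyl)methoxy in place of 4-fluorophenyl, on the aromatic carbon next to the ring nitrogen, brings a 3.1-fold higher number from compound 3 to compound 4 (0.49 log units; beyond the scatter) and gives the first readable step. It shows that clearance at this position responds to the exchange by more than the usual scatter, with the 4-fluorophenyl compound the lower of the two. Nothing available explains this rise.

The compounds shown leave open which part of the entering group carries the step, the hydroxyl or the four-membered ring. From the compounds shown here alone, how an amine or a carboxylic acid would behave at this place also remains open.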